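The compounds below may be only part of what the source reports. "The series", "measured", "known", "first", "only" and "open" are said of these compounds alone.

Compound 1 `C[Se]/C(=N\C(=O)c1cc2ccccc2s1)NC(=O)c1cc2ccccc2s1` gives 41000 nM in a functional assay on HepG2 cells (Homo sapiens) for cytotoxicity, read by MTT assay, with a stated time of 72 h; on this read-out lower numbers stand for stronger inhibition of growth and higher numbers for weaker inhibition of growth.
Compound 2 `CS/C(=N\C(=O)c1cc2ccccc2s1)NC(=O)c1cc2ccccc2s1` gives 53000 nM in this assay.

Compound 2 gives the highest of the two numbers measured in this assay, but the step from compound 1 is a 1.3-fold higher number from compound 1 to compound 2 (0.11 log units; within the scatter). Compound 3 `O=C(/N=C(/NC(=O)c1cc2ccccc2s1)[Se]Cc1ccccc1)c1cc2ccccc2s1` differs from compound 2 by a group of 8 heavy atoms (7 carbon, 1 selenium; one six-membered aromatic ring of carbon only) in place of a group of 2 heavy atoms (1 carbon, 1 sulfur; no ring), on a carbon with a double bond to nitrogen. Among the measured compounds shown here, the only measured step at this carbon, a 1.3-fold higher number from compound 1 to compound 2 (0.11 log units; within the scatter), bears on it, and it was within the scatter; nothing measured speaks to the benzyl part. For compound 3 a step of a 1.5-fold lower number from compound 2 to compound 3 (0.18 log units; within the scatter) in this assay is therefore expected, with no firm direction. The estimate for compound 3 is 35000 nM, within 12000 nM to 100000 nM.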

Compound 3, concentration for total growth inhibition: 49000 nM
For compound 3 the middle estimate is 1.4-fold (0.15 log units) below the measured one; the measured number falls inside the stated range.
By their numbers in this assay, from the lowest: compounds 1, 3 and 2 (each within the scatter of the next).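

Phenyl in place of hydrogen on the saturated chain carbon bound to the selenium atom gives a 1.2-fold higher number from compound 1 to compound 3 (0.08 log units; within the scatter) in this assay, so the first enlargement of this group leaves the reading within the scatter. The whole change from methylsulfanyl to the group of 8 heavy atoms gives a 1.1-fold lower number from compound 2 to compound 3 (0.03 log units; within the scatter) and is likewise within the scatter. No measurement available here explains these numbers.

The compounds shown leave open whether an amine or a carboxylic acid on this chain would give a step beyond the scatter. They also leave open how benzylsulfanyl would read against its selenium counterpart.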